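Hydroxy for Chloro on the Pyrimidine of Compound 2

A few compounds are considered here, and "the series" means these few. Any claim that something is new, unique, unknown or untested is made for them only; others in the source may bear on it.

Compound 1 `COc1cc(SC)nc2n/c(=N/C(=O)c3c(-c4ccc(Cl)cc4Cl)noc3C)sn12`: 68.3%
Compound 2 `Cc1cc(Cl)nc(NC(=S)NC(=O)c2c(-c3ccc(Cl)cc3Cl)noc2C)n1`: 48.3%

Both compounds were tested in a functional assay on the whole organism for inhibition, with Chenopodium ficifolium as the target, with a stated time of 72 h, tested at 100 mg/L; on this read-out lower numbers stand for less inhibition of growth and higher numbers for more inhibition of growth at the one concentration tested. Compound 2 stands lowest of the two numbers, and its gap to compound 1 lies beyond the usual scatter of repeated measurements.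

Compound 3 `Cc1cc(O)nc(NC(=S)NC(=O)c2c(-c3ccc(Cl)cc3Cl)noc2C)n1` has not yet been measured. It differs from compound 2 in one place: hydroxy in place of chloro on an aromatic carbon. For the measured compounds named here, no step between measured compounds is available, so nothing in the data shows how such a change acts in this assay. A moderate fall is nevertheless expected from compound 2 to compound 3, a number 13.3 percentage points lower from compound 2 to compound 3 (beyond the scatter). For compound 3 the estimated growth inhibition in this assay is 35%, within a range of 10% to 62%.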

Compound 3, percent growth inhibition at one concentration: 46.7%
Compound 3: middle estimate off by 11.7 percentage points, on the low side; low and high end bracket the measured number.
By their numbers in this assay, from the lowest: compounds 3 and 2 (each within the scatter of the next); then compound 1.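

In this assay, for the compounds shown here, the change from 4-chloro-6-methylpyrimidin-2-yl to 4-hydroxy-6-methylpyrimidin-2-yl gives the first readable step at this position: a number 1.6 percentage points lower from compound 2 to compound 3 (within the scatter). At this one concentration, compound 2 and compound 3 therefore cannot be told apart, although hydroxy brings a hydrogen-bond donor and acceptor that chloro lacks. Nothing available bears on why this exchange reads as it does.

Going by these compounds, whether an amine or a carboxylic acid at this position would also stay within the scatter of compound 2 remains open. On these data alone, compound 1 differs from both in more than one place, so what sets it apart stays open too.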